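Replacing Bromo with Dimethylamino on the Aromatic Ring

The source may hold more compounds than are shown below. What is called first, only, known or untested is meant among the compounds shown, and "the series" means these compounds.

Measured so far:
compound 1 `O=C(N/N=C/c1ccc(Cl)cc1Cl)Nc1cccc2ccccc12` gives 100 mg/kg
compound 2 `O=C(N/N=C/c1ccc(Br)cc1)Nc1cccc2ccccc12` gives 300 mg/kg

In a functional assay on the whole organism (strain Swiss albino) with Mus musculus as the target, in the maximal electroshock model, with a stated time of 0.5 h (a lower number here means that less compound is needed, a higher number that more compound is needed for the effect), compound 2 stands with the highest of the two numbers, and its nearest neighbour is compound 1. Among the compounds with values here, the only measured step, a 3.0-fold higher number from compound 1 to compound 2 (0.48 log units; beyond the scatter), came with a change of halogen pattern. Compound 3 `CN(C)c1ccc(/C=N/NC(=O)Nc2cccc3ccccc23)cc1` differs from compound 2 in one place: dimethylamino in place of bromo on an aromatic carbon. Within the data shown here, no measured step involves a dimethylamino group, so that single step bears little on this change. The step of no change at the digits printed from compound 2 to compound 3 (within the scatter) is therefore expected to stay within the scatter. Compound 3 is expected to give 300 mg/kg, within a range from 100 mg/kg to 1000 mg/kg.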

Compound 3, minimum effective dose: 100 mg/kg
Compound 3: the middle estimate sits 3.0-fold (0.48 log units) above what was measured; the range from low to high includes it.
By their numbers in this assay, from the lowest: compounds 1 and 3 (each within the scatter of the next); then compound 2.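

In this assay the swap of bromo for dimethylamino gives a 3.0-fold lower number from compound 2 to compound 3 (0.48 log units; beyond the scatter) on this aromatic carbon, so less compound is needed for the effect. The earlier step changed only the halogen pattern, whereas this one shows that a group that is not a halogen can sit at this position and still shift the dose beyond the scatter. Nothing available here accounts for this shift. Going by these compounds, whether a primary amine or a methoxy group at this position would shift the dose in the same way stays open.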